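Aryl Group Returned in Place of Isopropyl: Cytotoxicity Outlook

The source may report more compounds than this note shows. Statements on the series, on what has been measured and on what is new or still open speak of the compounds shown alone.

Compound 1, `Cc1ccccc1-c1nn(-c2ccccc2Cl)cc1CNCCN1CCN(C)CC1`: > 20000 nM
Compound 2, `Cc1ccccc1-c1nn(C(C)C)cc1CNCCN1CCN(C)CC1`: > 20000 nM

In an ADME assay on Huh-7 cells (Homo sapiens) for cytotoxicity (on this read-out lower numbers stand for higher toxicity in this test and higher numbers for lower toxicity in this test), compound 1 gives only a limit, > 20000 nM. Compound 2 likewise gives only a limit, > 20000 nM. Both values sit at the limit of > 20000 nM in this assay, at which 2 of the 2 values shown sit, so the step that the two limits leave unreadable from compound 1 to compound 2 stays unreadable. Compound 3, `Cc1ccccc1-c1nn(-c2cc(F)ccc2F)cc1CNCCN1CCN(C)CC1`, differs from compound 2 by 2,5-difluorophenyl in place of isopropyl on an aromatic nitrogen. Within the data shown here, no measured step bears a readable size on this change. For compound 3 the expected step is therefore a step that the limit leaves unreadable from compound 2 to compound 3, nothing beyond the scatter. In this assay compound 3 is estimated at 25000 nM, with a range from 10000 nM to 60000 nM.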

Compound 3, half-maximal cytotoxic concentration: > 20000 nM
Compound 3: no number, only a limit; the forecaster's own chance of this, stated with the estimate: 75%; the middle value lies beyond the limit too.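

Compound 1, compound 2 and compound 3 all give only a limit, so no step between them can be read: the limit of > 20000 nM in this assay, at which 3 of the 3 values shown sit.

As far as these compounds go, whether isopropyl, 2-chlorophenyl and 2,5-difluorophenyl on the aromatic nitrogen differ at all in this assay stays open.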